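A few compounds are considered here, and "the series" means these few. Any claim that something is new, unique, unknown or untested is made for them only; others in the source may bear on it.

Three glycoside-bearing and related diarylheptanoid-type compounds have so far been tested for growth inhibition of a leukaemia cell line. Compound 1 `Oc1ccc(CC[C@@H](O)C[C@H](O)CCc2ccc(O)c(O)c2)cc1O` carries two 3,4-dihydroxyphenyl ends and no sugar; in a functional assay on HL-60 cells (Homo sapiens) for cytotoxicity, read by MTT assay, with a stated time of 72 h (on this read-out lower numbers stand for stronger inhibition and higher numbers for weaker inhibition), compound 1 gives 1.8 ug/mL. Compound 2 `OC[C@H]1O[C@@H](O[C@H](CCc2ccc(O)c(O)c2)C[C@H](O)CCc2ccc(O)cc2)[C@H](O)[C@@H](O)[C@@H]1O` bears a glucose on one of the chain hydroxyls and gives 6.2 ug/mL in this assay. Its positional isomer compound 3 `OC[C@H]1O[C@@H](O[C@H](CCc2ccc(O)cc2)C[C@H](O)CCc2ccc(O)c(O)c2)[C@H](O)[C@@H](O)[C@@H]1O`, with the sugar on the other chain hydroxyl, gives 5.5 ug/mL in this assay. Among these three, compound 2 sits at the highest number; its gap to compound 3 is within the scatter of repeated measurements and allows no ordering, while its gap to compound 1 lies beyond the scatter.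

The next compound, compound 4 `COc1cc(CC[C@H](C[C@H](O)CCc2ccc(O)cc2)O[C@@H]2O[C@H](CO)[C@@H](O)[C@H](O)[C@H]2O)ccc1O`, differs from compound 2 in a single place (methyl in place of hydrogen on an oxygen on an aromatic ring). Within the data shown here, no pair of measured compounds shows this change, so no step in this assay can be borrowed to size it. Nothing in the data points one way or the other; the expectation is therefore of a step from compound 2 to compound 4 that stays within the scatter, a 1.2-fold higher number from compound 2 to compound 4 (0.08 log units; within the scatter). In this assay compound 4 is estimated at 7.5 ug/mL, with a range from 3.5 ug/mL to 16 ug/mL.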

Compound 4, half-maximal inhibitory concentration: > 10 ug/mL
Compound 4 ended at the assay's limit; the forecaster's own chance of this, stated with the estimate: 5%; at least 1.3-fold (0.12 log units) between middle value and limit.
By their numbers in this assay, from the lowest: compound 1; then compounds 3 and 2 (each within the scatter of the next). At a limit, above all of these: compound 4.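

Compound 4 reads > 10 ug/mL in this assay, and this is a limit of the assay and not a number. Among these compounds, this is the first view of a change on this oxygen on an aromatic ring: going from hydroxy to methoxy, which turns the 3,4-dihydroxyphenyl end into a 4-hydroxy-3-methoxyphenyl end, gives an at least 1.6-fold higher number from compound 2 to compound 4 (0.20 log units; that floor lies within the scatter). The methyl therefore brings no lower number here, but since the floor of the step stays within the scatter, a real loss is not established, and the reading gives a floor without a size, the only one of its kind among these compounds: the limit of > 10 ug/mL in this assay, at which 1 of the 4 values shown sits.

From the compounds shown here alone, it remains open how far the number truly rises with this methyl, and whether the same change would act alike on compound 1 or compound 3, where the surroundings of that oxygen differ. Going by these compounds, it is equally open whether a longer ether such as ethoxy, or an amine in the same place, would move the number in either direction.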